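The source may report more compounds than this note shows. Statements on the series, on what has been measured and on what is new or still open speak of the compounds shown alone.

Of the compounds shown here, two with a shared core have been measured in an assay on isolated protein for displacement of a labelled ligand from Apoptosis regulator Bcl-2 (Homo sapiens), read by fluorescence polarization; a higher number here means a weaker inhibitor, a lower number a stronger inhibitor. Compound 1 `COc1ccccc1CC1(OC)CCN(c2ccc(C(=O)NS(=O)(=O)c3ccc(N[C@H](CCN(C)C)CSc4ccccc4)c([N+](=O)[O-])c3)cc2)CC1` gives 1.6 nM. Compound 2 `CN(C)CC[C@H](CSc1ccccc1)Nc1ccc(S(=O)(=O)NC(=O)c2ccc(N3CCC(=Cc4ccc(F)cc4)CC3)cc2)cc1[N+](=O)[O-]` gives 3.4 nM, which is the higher of the two numbers; the gap to compound 1 is beyond the usual scatter of repeated measurements, so compound 2 is the weaker of the pair in this assay. Compound 3 `CN(C)CC[C@H](CSc1ccccc1)Nc1ccc(S(=O)(=O)NC(=O)c2ccc(N3CCC(=Cc4ccccc4C#N)CC3)cc2)cc1[N+](=O)[O-]` is not yet measured. It differs from compound 2 in one place: 2-cyanophenyl in place of 4-fluorophenyl on a double-bonded chain carbon bound to a double-bonded ring carbon. Among the compounds with values here, no step between two measured compounds involves this kind of change, so there is no direct guide to its size. On the numbers shown, a move no larger than the scatter in either direction seems most likely. Compound 3 is therefore expected to give about 3 nM in this assay, within a range of 1.2 nM to 8 nM, meaning an expected step of a 1.1-fold lower number from compound 2 to compound 3 (0.05 log units; within the scatter).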

Compound 3, inhibition constant: 13 nM
Compound 3: middle estimate off by 4.3-fold (0.64 log units), on the low side, and the stated range ends below it.
By their numbers in this assay, from the lowest: compound 1; then compound 2; then compound 3.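

Replacing 4-fluorophenyl with 2-cyanophenyl on a double-bonded chain carbon bound to a double-bonded ring carbon gives a 3.8-fold higher number from compound 2 to compound 3 (0.58 log units; beyond the scatter) in this assay, so this position does respond to what it carries. The change weakens binding without abolishing it, as compound 3 still gives 13 nM in this assay. No measurement shown here accounts for the loss.

The swap alters both the group on the aromatic ring and where that group sits, and the compounds shown cannot separate these two changes. A 2-fluorophenyl or a 4-cyanophenyl at this place would tell them apart, while an unsubstituted phenyl would show whether the ring needs either group at all.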